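The compounds below may be only part of what the source reports. "The series", "measured", "known", "first", "only" and "open" are said of these compounds alone.

The measured compounds and their values:

Compound 1, `Nc1cc(N)c2nc(-c3ccccc3)c(NCc3ccc(Cl)c(Cl)c3)nc2c1`: 22400 nM
Compound 2, `CCOC(=O)[C@H](CCC(=O)O)NC(=O)c1ccc(Sc2nc3cc(N)cc(N)c3nc2-c2ccccc2)cc1`: < 100000 nM
Compound 3, `Nc1cc(N)c2nc(-c3ccccc3)c(Sc3ccc(F)cc3)nc2c1`: < 100000 nM

The study is read in a functional assay on NCI-H522 cells (Homo sapiens) for inhibition, read by sulforhodamine B assay, with a stated time of 48 h; a lower number here means that less compound is tolerated, a higher number that more compound is tolerated. Compound 1 gives 22400 nM as a number. For compound 2 the result is a limit of the assay, < 100000 nM, and not a number. For compound 3 the result is likewise a limit, < 100000 nM, so compound 3 stands only at the edge of what the assay can report, a position it shares with compound 2, as the line the limit of < 100000 nM in this assay, at which 2 of the 3 values shown sit, shows. Going by the values given here, compound 1 is the only compound among the three with a measured number.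

Compound 4, `Nc1cc(N)c2nc(-c3ccccc3)c(Sc3ccc(Cl)c(Cl)c3)nc2c1`, has not been measured. It differs from compound 3 by 3,4-dichlorophenyl in place of 4-fluorophenyl on a sulfur. Among the compounds with values here, no step between measured compounds is available that isolates this change. Compound 3 itself stands only at a limit of the assay. The expectation therefore rests on that and on compound 1 giving 22400 nM with a 3,4-dichlorophenyl bearing group on a different linker. The step from compound 3 to compound 4 is expected to be a step that the limit leaves unreadable from compound 3 to compound 4, toward a lower number, though a result at the limit again would not surprise. Compound 4 is accordingly expected to give about 40000 nM, between 10000 nM and 100000 nM.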

Compound 4, concentration lethal to 50% of the cells: < 100000 nM
Compound 4: no number, only a limit; the forecaster's own chance of this, stated with the estimate: 50%; the middle value is on the limit's open side.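

In this assay compound 4 gives < 100000 nM, a limit of the assay and not a number. Compound 3 also stands only at a limit, so no step can be read between compound 3 and compound 4. The compounds shown leave open whether 3,4-dichlorophenyl in place of 4-fluorophenyl on a sulfur changes the read-out at all.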